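This account rests on a few compounds, and the source may have more. Where it says the series, first, only, none or still open, it means among the compounds named here.

Measured so far in an assay on Cerebral cortex for displacement of a labelled ligand from adenosine receptor A1 (Bos taurus); on this read-out higher numbers stand for weaker inhibition and lower numbers for stronger inhibition:
compound 1 `CCNc1nc(-c2ccccc2)nc2c1nnn2Cc1ccccc1` gives 91 nM
compound 2 `CCCCCCNc1nc(-c2ccccc2)nc2c1nnn2Cc1ccccc1` gives 13.2 nM
compound 3 `CCCCCCNc1nc(-c2ccccc2)nc2c1nnn2Cc1ccccc1C(F)(F)F` gives "not determined" (no result reported) in this assay, so no number is available for it.

Going by the values given here, compound 2 stands at the lowest of the two numbers; the only step to compare is the one from compound 1 to compound 2, a 6.9-fold lower number from compound 1 to compound 2 (0.84 log units; beyond the scatter), where hexyl in place of ethyl on the chain nitrogen brought the number down. Compound 4 `OCCCNc1nc(-c2ccccc2)nc2c1nnn2Cc1ccccc1` differs from compound 2 by hydroxy in place of propyl on a saturated chain carbon, three bonds along the chain from a nitrogen on an aromatic ring. Among the compounds with values here, the move back to a shorter chain follows the direction of compound 1, and no measured step covers the hydroxy itself. A modest rise in the number is therefore expected, an 11-fold higher number from compound 2 to compound 4 (1.06 log units; beyond the scatter), placing compound 4 near or above compound 1. Compound 4 is estimated at 150 nM, with a range of 40 nM to 600 nM.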

Compound 4, inhibition constant: 21.4 nM
Beside the measured number, compound 4's estimate is 7.0-fold (0.85 log units) above it, and the stated range ends above it.
By their numbers in this assay, from the lowest: compounds 2 and 4 (each within the scatter of the next); then compound 1.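

In this assay, hydroxy in place of propyl on a saturated chain carbon, three bonds along the chain from a nitrogen on an aromatic ring, gives a 1.6-fold higher number from compound 2 to compound 4 (0.21 log units; within the scatter) and leaves the two compounds level. An all-carbon hexyl chain is thus not required for the drop from compound 1, since the 3-hydroxypropyl chain also gives a 4.3-fold lower number from compound 1 to compound 4 (0.63 log units; beyond the scatter) while adding a hydrogen-bond donor and acceptor. Nothing available explains this result.

Still open, as far as these compounds go, is whether an amine or a carboxylic acid in place of hydroxy on this chain keeps the number, and whether hydroxy on a longer chain does so too. The trifluoromethyl group of compound 3 cannot be read, as that compound has no number.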